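The compounds below may be only part of what the source reports. "The series", "measured", "known", "first", "only" and "open" are said of these compounds alone.

Compound 1 `COc1ccc2ncc(S(=O)(=O)c3ccc(C)cc3)c(N3CCC(C)CC3)c2c1`: 90%
Compound 2 `Cc1ccc(S(=O)(=O)c2cnc3ccc(C)cc3c2N2CCC(C)CC2)cc1`: 82%
Compound 3 `Cc1ccc(S(=O)(=O)c2cnc3ccc(F)cc3c2N2CCC(C)CC2)cc1`: 91%

All three were tested in an assay on isolated protein for displacement of a labelled ligand from metabotropic glutamate receptor 5 (Homo sapiens), with a stated time of 60 min, tested at 1 uM; on this read-out lower numbers stand for less inhibition and higher numbers for more inhibition at the one concentration tested (going by the name of the read-out). Compound 1 stands second highest of the three numbers, with compound 3 nearest at a number 1 percentage points higher from compound 1 to compound 3 (within the scatter) and compound 2 furthest at a number 8 percentage points lower from compound 1 to compound 2 (within the scatter); both gaps lie within the scatter, so the three cannot be ranked. Compound 4 `COc1ccc2ncc(S(=O)(=O)c3cccc(F)c3)c(N3CCC(C)CC3)c2c1` differs from compound 1 by 3-fluorophenyl in place of 4-methylphenyl on a sulfonyl sulfur. For the measured compounds named here, no measured step touches the sulfonyl sulfur: a number 8 percentage points lower from compound 1 to compound 2 (within the scatter), a number 1 percentage points higher from compound 1 to compound 3 (within the scatter) and a number 9 percentage points higher from compound 2 to compound 3 (within the scatter) each swap a group on an aromatic carbon of the shared core, and every one stayed within the scatter. The data therefore give no direct guide, only a sense that small swaps have so far changed little. Compound 4 is expected to give 84%, between 62% and 97%. The expected step is a number 6 percentage points lower from compound 1 to compound 4 (within the scatter), not beyond the scatter.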

Compound 4, a percentage reported as inhibition, at one concentration (the size of the read-out at that concentration, not a potency): 68%
Estimate against measurement, compound 4: 16 percentage points above; low and high end bracket the measured number.
By their numbers in this assay, from the lowest: compound 4; then compounds 2, 1 and 3 (each within the scatter of the next).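

The group on the sulfonyl sulfur counts for more than the earlier swaps suggested: 3-fluorophenyl in place of 4-methylphenyl gives a number 22 percentage points lower from compound 1 to compound 4 (beyond the scatter), whereas every swap on an aromatic carbon of the shared core stayed within the scatter. The two groups have the same count of heavy atoms, so that count does not separate them. Nothing measured here accounts for the fall.

Still open, going by these compounds, is whether the fall goes with losing the methyl or with gaining the fluorine. On these data alone, how plain phenyl or 4-aminophenyl would fare on the sulfonyl sulfur is also open.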